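Side-chain shortening at the aromatic carbon of the shared core

The source may report more compounds than this note shows. Statements on the series, on what has been measured and on what is new or still open speak of the compounds shown alone.

Compound 2 `CCC/C=C/c1c(C)nn(CCCN2CCN(c3ccc(C)cc3)CC2)c(=O)c1N` is the lower of the two numbers measured in a functional assay on the whole organism (Abdomen, strain Swiss) for inhibition, with Mus musculus as the target, with stated times of 30 min, 10 min and 5 min, at a dose of 10 mg/kg by the oral route; on this read-out lower numbers stand for a weaker effect and higher numbers for a stronger effect at the one dose given; in this assay compound 2 gives 0%. The nearest measured neighbour is compound 1 `CCCCC(=O)c1c(C)nn(CCCN2CCN(c3ccc(C)cc3)CC2)c(=O)c1N`, which in this assay gives 8%; the step of a number 8 percentage points lower from compound 1 to compound 2 (within the scatter) lies within the scatter, so the two are not distinguished. Compound 3 `CCc1c(C)nn(CCCN2CCN(c3ccc(C)cc3)CC2)c(=O)c1N` is not yet measured. It differs from compound 2 as follows: ethyl in place of pent-1-en-1-yl on an aromatic carbon. Among the measured compounds shown here, only the step from compound 1 to compound 2 bears on this change, and it was within the scatter; both measured compounds sit near the bottom of the read-out, which leaves no measured movement to extrapolate. The step of a number 3 percentage points higher from compound 2 to compound 3 (within the scatter) is therefore expected to stay within the scatter. For compound 3 the value in this assay is estimated at 3%, with a range from 0% to 15%.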

Compound 3, a percentage reported as inhibition, in the whole organism at one dose (the size of the read-out at that dose, not a potency): 23%
Compound 3: middle estimate off by 20 percentage points, on the low side; measured number above the stated range.
By their numbers in this assay, from the lowest: compounds 2 and 1 (each within the scatter of the next); then compound 3.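

In this assay, the aromatic carbon opposite the ring nitrogen now shows a response to its substituent that the first pair could not show: ethyl in place of pent-1-en-1-yl gives a number 23 percentage points higher from compound 2 to compound 3 (beyond the scatter), and ethyl in place of butylcarbonyl gives a number 15 percentage points higher from compound 1 to compound 3 (beyond the scatter). The two longer groups remain within the scatter of each other, so the shorter ethyl group is the one that separates from both, with or without a carbonyl or double bond in the longer group. No evidence on hand accounts for this difference.

As far as these compounds go, whether a methyl group or a propyl chain at this carbon would read like ethyl remains open. Also open, from the compounds shown here alone, is how a polar group there, such as an amine or a carboxylic acid, would read at this single dose, which gives no potency.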